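Changing the Ring on the Thioxothiazolidinone Nitrogen

The compounds below may be only part of what the source reports. "The series", "measured", "known", "first", "only" and "open" are said of these compounds alone.

Among the measured compounds shown here, compound 2 `CCCC[C@H](NC(=O)[C@H](CCCCN)NC(=O)[C@H](CCCNC(=N)N)NC(=O)c1ccc(/C=C2\SC(=S)N(c3ccc(Cl)cc3)C2=O)cc1)C(N)=O` has the highest of the two numbers so far in an ADME assay for permeability, using PAMPA (a higher number here means that the compound crosses the layer faster, a lower number that the compound crosses the layer more slowly), giving 1.02 10^-6 cm/s. Its nearest neighbour, compound 1 `CCCC[C@H](NC(=O)[C@H](CCCCN)NC(=O)[C@H](CCCNC(=N)N)NC(=O)c1ccc(/C=C2\SC(=S)N(Cc3ccc(OC)cc3)C2=O)cc1)C(N)=O`, gives 0.6 10^-6 cm/s in this assay, and the step of a 1.7-fold higher number from compound 1 to compound 2 (0.23 log units; within the scatter) stays within the usual scatter, so the two stand together. Compound 3 `CCCC[C@H](NC(=O)[C@H](CCCCN)NC(=O)[C@H](CCCNC(=N)N)NC(=O)c1cccs1)C(N)=O` is reported in this assay as "impermeable" (no number reported), with no number given. Compound 4 `CCCC[C@H](NC(=O)[C@H](CCCCN)NC(=O)[C@H](CCCNC(=N)N)NC(=O)c1ccc(/C=C2\SC(=S)N(C3CCCC3)C2=O)cc1)C(N)=O` is not yet measured and differs from compound 2 by cyclopentyl in place of 4-chlorophenyl on an amide-type nitrogen in a ring. For the measured compounds named here, the one step that bears on this change, a 1.7-fold higher number from compound 1 to compound 2 (0.23 log units; within the scatter), altered the group on that same ring nitrogen without leaving the scatter, so no step beyond the scatter is expected now. Compound 4 is therefore estimated at 0.8 10^-6 cm/s, between 0.3 10^-6 cm/s and 2 10^-6 cm/s, an expected step of a 1.3-fold lower number from compound 2 to compound 4 (0.11 log units; within the scatter).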

Compound 4, apparent permeability: 2.31 10^-6 cm/s
Estimate against measurement, compound 4: 2.9-fold (0.46 log units) below; measured number outside the range, above it.
By their numbers in this assay, from the lowest: compounds 1 and 2 (each within the scatter of the next); then compound 4.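

On the amide-type nitrogen in the ring, the group can shift the number in this assay beyond the scatter, which the earlier step did not show: cyclopentyl in place of 4-chlorophenyl gives a 2.3-fold higher number from compound 2 to compound 4 (0.36 log units; beyond the scatter), and cyclopentyl in place of 4-methoxybenzyl gives a 3.9-fold higher number from compound 1 to compound 4 (0.59 log units; beyond the scatter). Of these three compounds, only compound 4 carries a non-aromatic ring there. Nothing measured here gives a reason for the rise. On these data alone, whether cyclohexyl, a butyl chain or a group carrying an amine would give a similar number remains open.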